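The source may hold more compounds than are shown below. What is called first, only, known or untested is meant among the compounds shown, and "the series" means these compounds.

Measured so far in a functional assay on brain (Rattus norvegicus, strain Wistar) for inhibition; a higher number here means a weaker inhibitor, a lower number a stronger inhibitor:
compound 1, `CCCCn1c(-c2ccccc2)c(C)[nH]c1=O`: > 100000 nM
compound 2, `Cc1ccc(-c2c(C)[nH]c(=O)n2C)cc1`: 85300 nM

Compound 1 reaches only a limit in this assay, > 100000 nM, which is a limit and not a number. For the measured compounds named here, compound 2 holds the only number; the one other value shown is a limit, (the limit of > 100000 nM in this assay, at which 1 of the 2 values shown sits). Going by the values given here, no step between two measured compounds is available, so the size of any structural change in this assay is still unanchored.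

Compound 3, `CCCCCCc1ccc(-c2c(C)[nH]c(=O)n2C)cc1`, is not yet measured in this assay. It differs from compound 2 in one place: pentyl in place of hydrogen on a saturated chain carbon bound to an aromatic carbon. Among the compounds with values here, no measured pair shows what such a chain extension does here. The step from compound 2 to compound 3 is expected to be a moderate move toward stronger inhibition, a 2.8-fold lower number from compound 2 to compound 3 (0.45 log units; beyond the scatter), though a change within the scatter cannot be excluded. Compound 3 is therefore expected near 30000 nM, with a range from 8000 nM to 120000 nM.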

Compound 3, half-maximal inhibitory concentration: 9000 nM
Estimate against measurement, compound 3: 3.3-fold (0.52 log units) above; the range from low to high includes it.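

The saturated chain carbon bound to an aromatic carbon accepts a substantial extension in this assay: pentyl in place of hydrogen there, which can also be read as methyl to hexyl, gives stronger inhibition (a 9.5-fold lower number from compound 2 to compound 3 (0.98 log units; beyond the scatter)). For the compounds shown here, this is the only step so far, and it shows that a chain of this length at this position brings a gain beyond the scatter rather than a loss. The values shown give no cause for this step.

Going by these compounds, whether the gain builds steadily from methyl to hexyl, or continues with a longer chain such as octyl, stays open. Also open, on these data alone, is whether an amine or a carboxylic acid at the end of the hexyl chain would keep the gain.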